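Fluoro to hydrogen on the aryl of compound 2

The compounds below may be only part of what the source reports. "The series", "measured", "known", "first", "only" and "open" are said of these compounds alone.

Three compounds of the series carry numbers in a functional assay on HEK293 cells for agonist activity at D(4) dopamine receptor (Homo sapiens), read by FLIPR; on this read-out lower numbers stand for smaller maximal responses and higher numbers for larger maximal responses. Compound 1 `COc1ccccc1C1CCN(CC(=O)Nc2cccc(C)c2)CC1` gives 43%, compound 2 `Cc1cccc(NC(=O)CN2CCC(c3cccc(F)c3)CC2)c1` gives 40%, and compound 3 `Cc1cccc(C(=O)NCN2CCC(c3ccccn3)CC2)c1` gives 67%. On these numbers compound 2 stands lowest; its nearest neighbour is compound 1, within the scatter of it, its furthest compound 3, beyond the scatter. Compound 3 differs from compound 2 in more than one place, so only its value is known, not a single-change step.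

Compound 4 `Cc1cccc(NC(=O)CN2CCC(c3ccccc3)CC2)c1` is unmeasured. It differs from compound 2 by hydrogen in place of fluoro on an aromatic carbon.

Among the compounds with values here, the one step that bears on this is the swap of the aryl on the saturated ring carbon: a number 3 percentage points lower from compound 1 to compound 2 (within the scatter). Nothing in the shown data points to a change beyond the scatter for removing fluoro from that aryl. Compound 4 is therefore expected to give about 42%, within 28% to 58% in this assay. The expected step from compound 2 to compound 4 is a number 2 percentage points higher from compound 2 to compound 4 (within the scatter), within the scatter.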

Compound 4, largest response reached (reported as efficacy), in percent of the reference or control that the assay uses: 37%
Compound 4: middle estimate off by 5 percentage points, on the high side, within the range that was stated.
By their numbers in this assay, from the lowest: compounds 4, 2 and 1 (each within the scatter of the next); then compound 3.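

In this assay the unsubstituted phenyl gives this position a reference: hydrogen in place of fluoro reads as a number 3 percentage points lower from compound 2 to compound 4 (within the scatter) and hydrogen in place of methoxy reads as a number 6 percentage points lower from compound 1 to compound 4 (within the scatter) on the same aromatic ring position of the series. Before this, 3-fluorophenyl and 2-methoxyphenyl could only be set against each other; now, across compound 1, compound 2 and compound 4, neither fluoro nor methoxy stands apart from hydrogen beyond the scatter. Nothing at hand offers an explanation for these steps.

Going by these compounds, whether an amine or a carboxylic acid on this aromatic carbon would give a step beyond the scatter remains open. Also open, on these data alone, is which of its several differences goes with the value of compound 3 at 67% in this series.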